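The compounds below may be only part of what the source reports. "The series", "measured", "known", "first", "only" and "open" are said of these compounds alone.

Working notes on the series. In a functional assay on DU-145 cells (Homo sapiens) for antiproliferative activity, read by MTT assay, with a stated time of 72 h (a higher number here means a weaker inhibitor, a lower number a stronger inhibitor), compound 1 (`NC1CCc2nc(-c3ccncc3)nc(Nc3cccc(F)c3)c2C1`) gives 15100 nM. Compound 2 (`CN(C)c1ccc(Nc2nc(-c3ccncc3)nc3c2CC(N)CC3)cc1`) gives 11500 nM, and compound 3 (`COc1cccc(Nc2nc(-c3ccncc3)nc3c2CC(N)CC3)c1`) gives 8800 nM. Compound 1 cannot be told apart from the other two: the data show a 1.3-fold lower number from compound 1 to compound 2 (0.12 log units; within the scatter) and a 1.7-fold lower number from compound 1 to compound 3 (0.23 log units; within the scatter), and the remaining pair shows a 1.3-fold lower number from compound 2 to compound 3 (0.12 log units; within the scatter).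

Compound 4 (`N[C@H]1CCc2nc(-c3ccncc3)nc(Nc3cccc(F)c3)c2C1`) has not yet been measured. Against compound 1, the difference is the two compounds have the same atoms and bonds; at least one stereo element is drawn with a configuration in one of them and without one in the other: 1 of 1 stereo elements differ; a stereocentre at a saturated ring carbon is drawn without a configuration in compound 1 and S in compound 4. Within the data shown here, the atoms and bonds stay the same, and the only change is at the stereocentre at a saturated ring carbon, which is drawn without a configuration in compound 1 and with one in compound 4.

Among the measured compounds shown here, none of the measured steps touches that stereocentre, as all three alter the aromatic substituent instead. For the measured compounds named here, the series holds no pair differing in configuration alone, and the data do not state the stereochemical composition of the sample of compound 1. The expectation therefore rests on compound 1 at 15100 nM, with no step beyond the scatter expected in this assay and no direction supported. The expected step is a 1.1-fold lower number from compound 1 to compound 4 (0.03 log units; within the scatter). Compound 4 is estimated at 14000 nM, with an expected range of 7000 nM to 28000 nM.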

Compound 4, half-maximal inhibitory concentration: 17900 nM
Compound 4: the middle estimate sits 1.3-fold (0.11 log units) below what was measured, within the range that was stated.
By their numbers in this assay, from the lowest: compounds 3, 2, 1 and 4 (each within the scatter of the next, the first and the last beyond it).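

Defining the stereocentre at a saturated ring carbon as S gives a 1.2-fold higher number from compound 1 to compound 4 (0.07 log units; within the scatter), so in this assay this change cannot be told apart from the compound drawn without a configuration. Among these compounds, until now, every step had altered the aromatic substituent, so this is the first reading at this position, and it shows no separation on the 3-fluorophenyl compound. The reading has a limit, since the sample composition of compound 1 is not stated and the step therefore compares a defined drawing with an undefined one, not two known configurations: the fact that one of compounds 1 and 4 is drawn with a defined configuration and the other without, at the place where they differ

Open questions remain at this position: how the R configuration reads, and whether S behaves the same way alongside 3-methoxyphenyl or 4-(dimethylamino)phenyl on the ring nitrogen substituent. Also open, as far as these compounds go, is whether anything at that saturated ring carbon other than the primary amine, such as a hydroxyl, a dimethylamino group or an acetamide, moves the number in this assay beyond the scatter.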